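Chloro for Bromo: Expected Effect on Cell Growth Inhibition

The source may report more compounds than this note shows. Statements on the series, on what has been measured and on what is new or still open speak of the compounds shown alone.

Compound 1 `O=C(/C=C/c1ccc(Cl)cc1)Nc1cc(-c2ccc(Br)cc2)[nH]n1` gives 1210 nM in a functional assay on A549 cells (Homo sapiens) for antiproliferative activity, read by MTT assay, with a stated time of 48 h; on this read-out higher numbers stand for weaker inhibition and lower numbers for stronger inhibition.
Compound 2 `Cc1ccc(-c2cc(NC(=O)/C=C/c3ccc(C(F)(F)F)cc3)n[nH]2)cc1` gives 1020 nM in this assay.
Compound 3 `Cc1ccc(-c2cc(NC(=O)/C=C/c3ccc(Br)cc3)n[nH]2)cc1` gives 1590 nM in this assay.

Compound 3 has the highest of the three numbers, yet its gaps to compound 1 and to compound 2 both lie within the scatter, so no order among them can be claimed. Compound 4 `Cc1ccc(-c2cc(NC(=O)/C=C/c3ccc(Cl)cc3)n[nH]2)cc1` differs from compound 3 by chloro in place of bromo on an aromatic carbon. Among the measured compounds shown here, the one measured step of a single change, a 1.6-fold higher number from compound 2 to compound 3 (0.19 log units; within the scatter), stayed within the scatter. Compound 1 also carries the chloro group, though its other ring differs, and its value and that of compound 3 lie within the scatter of each other. No step beyond the scatter is therefore expected. Compound 4 is expected at 1300 nM, with a range of 700 nM to 2500 nM. This estimate means a step of a 1.2-fold lower number from compound 3 to compound 4 (0.09 log units; within the scatter), expected to stay within the scatter.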

Compound 4, half-maximal inhibitory concentration: 1490 nM
For compound 4 the middle estimate is 1.1-fold (0.06 log units) below the measured one; measured number inside the range.
By their numbers in this assay, from the lowest: compounds 2, 1, 4 and 3 (each within the scatter of the next).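

In this assay, among the compounds shown here, chloro in place of bromo on the aromatic carbon para to a large group gives a 1.1-fold lower number from compound 3 to compound 4 (0.03 log units; within the scatter) as the first direct reading of this change. Chloro in place of trifluoromethyl gives a 1.5-fold higher number from compound 2 to compound 4 (0.16 log units; within the scatter) at that same place, so bromo, chloro and trifluoromethyl cannot be told apart there. Methyl in place of bromo gives a 1.2-fold higher number from compound 1 to compound 4 (0.09 log units; within the scatter) on the other aromatic ring, so that place shows no step beyond the scatter either. Going by these compounds, whether an amine, a carboxylic acid or a longer chain at the first place would move the number beyond the scatter stays open. Nothing available explains why these numbers lie so close.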